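The source may report more compounds than this note shows. Statements on the series, on what has been measured and on what is new or still open speak of the compounds shown alone.

Measured so far:
compound 1, `C=C1CCCC(C)(C)C1CC[C@]1(C)CC[C@@H]([C@@H](C)C(=O)O)OO1` — > 10000 nM
compound 2, `C=C1CCCC(C)(C)C1CC[C@]1(C)CC[C@H]([C@@H](C)C(=O)OC)OO1` — 7900 nM

The study follows a pair of stereoisomers of a peroxide-bridged acid. Growth inhibition was measured in a functional assay on EKVX cells (Homo sapiens) for inhibition; a higher number here means a weaker inhibitor of growth, a lower number a stronger inhibitor of growth. In this assay compound 1 gives > 10000 nM, which is a limit of the assay and not a number, so the compound can only be placed at the weak end of the measurements (the limit of > 10000 nM in this assay, at which 1 of the 2 values shown sits). Among the compounds with values here, compound 2, the methyl ester with a different configuration at one ring carbon, gives 7900 nM in this assay; the two compounds differ in more than one place, so no single step joins them.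

The next compound, compound 3, `C=C1CCCC(C)(C)C1CC[C@@]1(C)CC[C@H]([C@@H](C)C(=O)O)OO1`, has not yet been measured in this assay. It differs from compound 1 as follows: the two compounds have the same atoms and bonds; at least one stereo element is drawn with a configuration in one of them and without one in the other: 2 of 4 stereo elements differ; a stereocentre at a saturated ring carbon is drawn R in compound 1 and S in compound 3; a stereocentre at a saturated ring carbon is drawn S in compound 1 and R in compound 3. Within the data shown here, no measured step between compounds differing only in this way is available, so the size of the change is uncertain. Both acids are expected to remain weak, and the step from compound 1 to compound 3 is expected to be a step that the limit leaves unreadable from compound 1 to compound 3, none beyond the scatter. Compound 3 is therefore estimated at 12000 nM, within 4000 nM to 40000 nM.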

Compound 3, concentration for 50% growth inhibition: 3190 nM
Beside the measured number, compound 3's estimate is 3.8-fold (0.58 log units) above it, and the stated range ends above it.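

Changing only the drawn configuration at two saturated ring carbons, with atoms and bonds left the same, gives a measurable shift for the acid in this assay: an at least 3.1-fold lower number from compound 1 to compound 3 (0.49 log units; beyond the scatter), and compound 3 gives 3190 nM, so stereochemistry alone can move this series beyond the scatter. On these data alone, compound 1 gives > 10000 nM, which is a limit of the assay and not a number, so the true size of the step stays unknown and only its lower bound can be read: the limit of > 10000 nM in this assay, at which 1 of the 3 values shown sits. The comparison also carries a caveat in how the two structures are drawn: the fact that one of compounds 1 and 3 is drawn with a defined configuration and the other without, at the place where they differ

The compounds shown leave open whether one of the two ring carbons alone accounts for the step, since the two change together between compound 1 and compound 3. They also leave open how an amide or a primary alcohol in place of the carboxylic acid would read on the core of compound 3 in this assay.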